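Working notes: 3,5-dimethoxyphenyl to 3,5-dihydroxyphenyl

This account rests on a few compounds, and the source may have more. Where it says the series, first, only, none or still open, it means among the compounds named here.

Measured so far in a functional assay on MCF7 cells (Homo sapiens) for antiproliferative activity, read by MTT assay, with a stated time of 72 h (a higher number here means a weaker inhibitor, a lower number a stronger inhibitor), as follows:
- compound 1 `O=S(=O)(Oc1ccc(O)cc1)C1CC2OC1C(c1ccc(/C=C/c3cc(O)cc(O)c3)cc1)=C2c1ccc(O)cc1` at 14100 nM 
- compound 2 `COc1cc(/C=C/c2ccc(OS(=O)(=O)C3CC4OC3C(c3ccc(O)cc3)=C4c3ccc(O)cc3)cc2)cc(OC)c1` at 3700 nM 

Compound 2 holds the lower of the two numbers, and its gap to compound 1 lies beyond the usual scatter. The next compound to read is compound 3 `O=S(=O)(Oc1ccc(/C=C/c2cc(O)cc(O)c2)cc1)C1CC2OC1C(c1ccc(O)cc1)=C2c1ccc(O)cc1` which has no value yet. It differs from compound 2 in one place. The change is 3,5-dihydroxyphenyl in place of 3,5-dimethoxyphenyl on a double-bonded chain carbon bound to a double-bonded chain carbon and it puts 3,5-dihydroxyphenyl in place of 3,5-dimethoxyphenyl on a double-bonded chain carbon bound to a double-bonded chain carbon.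

Going by the values given here, no measured pair shows this change alone, so its size can only be estimated. Among the compounds with values here, the one hint is that compound 1, which also carries a 3,5-dihydroxyphenyl, reads 14100 nM against compound 2 at 3700 nM in this assay and that pair differs in more than this group. A moderate step toward a higher number, meaning a weaker inhibitor, is therefore expected. The estimated change is a 2.2-fold higher number from compound 2 to compound 3 (0.33 log units; beyond the scatter) by this expectation. Expected for compound 3 is 8000 nM with a range of 3000 nM to 20000 nM as estimated.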

Compound 3, half-maximal inhibitory concentration: 10500 nM
Compound 3: the middle estimate sits 1.3-fold (0.12 log units) below what was measured; measured number inside the range.
By their numbers in this assay, from the lowest: compound 2; then compounds 3 and 1 (each within the scatter of the next).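

this assay now gives a first clean reading of this change on its own, a 2.8-fold higher number from compound 2 to compound 3 (0.45 log units; beyond the scatter), a modest step toward a weaker inhibitor that lies beyond the scatter. At this place, on a double-bonded chain carbon bound to a double-bonded chain carbon, the 3,5-dimethoxyphenyl group of compound 2 therefore reads better than the 3,5-dihydroxyphenyl group of compound 3, although this rests on a single pair and sets no pattern beyond it. The entering group carries 2 hydrogen-bond donors and the leaving group 0, with 2 hydrogen-bond acceptors on each side, but no measurement at hand links that difference to the step.

On these data alone, whether the step follows the donors, the methyl caps or something else remains open, and a 3,5-difluorophenyl or a 3,5-diaminophenyl group at the same place would help to separate these readings. Also open is whether the same change would read alike in the arrangement of compound 1, for which no 3,5-dimethoxyphenyl partner is among the compounds shown.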